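This account rests on a few compounds, and the source may have more. Where it says the series, first, only, none or still open, it means among the compounds named here.

The three measured compounds share one core and differ only in the group attached to it. Compound 3 `COc1ccc(Sc2nc3cc(N)cc(N)c3nc2-c2ccccc2)cc1` carries a (4-methoxyphenyl)sulfanyl group. In a functional assay on OVCAR-8 cells (Homo sapiens) for inhibition, read by sulforhodamine B assay, with a stated time of 48 h (on this read-out lower numbers stand for higher toxicity in this test and higher numbers for lower toxicity in this test), compound 3 gives < 100000 nM, which is a limit of the assay, not a number. Compound 1 `Nc1cc(N)c2nc(-c3ccccc3)c(Oc3ccc(Cl)c(Cl)c3)nc2c1` carries 3,4-dichlorophenoxy instead. In this assay compound 1 gives < 100000 nM, likewise a limit. Compound 2 `Nc1cc(N)c2nc(-c3ccccc3)c(NCc3ccc(F)cc3)nc2c1` carries (4-fluorobenzyl)amino, and in this assay compound 2 gives 21900 nM. The steps a step that the limit leaves unreadable from compound 1 to compound 2, a step that the two limits leave unreadable from compound 1 to compound 3 and a step that the limit leaves unreadable from compound 2 to compound 3 cannot be sized because of the limit of < 100000 nM in this assay, at which 2 of the 3 values shown sit. Compound 4 `Nc1cc(N)c2nc(-c3ccccc3)c(Sc3ccc(Cl)c(Cl)c3)nc2c1` differs from compound 3 by 3,4-dichlorophenyl in place of 4-methoxyphenyl on a sulfur. No readable measured step bears on this change. Compound 4 is expected near 60000 nM, between 15000 nM and 200000 nM, and may again be reported only as a limit. The expected step that the limit leaves unreadable from compound 3 to compound 4 is therefore small.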

Compound 4, concentration lethal to 50% of the cells: < 100000 nM
Compound 4: only a limit was reported; the forecaster's own chance of this, stated with the estimate: 60%; the middle value does not contradict the limit.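

The result for compound 4 is a limit of the assay, not a number, so no new step to compound 1, compound 2 or compound 3 can be read because of this: the limit of < 100000 nM in this assay, at which 3 of the 4 values shown sit.

On these data alone, how far the groups on the shared core separate these four compounds in this assay stays open.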